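The compounds below may be only part of what the source reports. "The series", "measured", "known", "first", "only" and "open" are said of these compounds alone.

Of the compounds shown here, three of a shared core have been tested in an assay on isolated protein for inhibition of aldehyde dehydrogenase 1A1 (Homo sapiens), read by spectrophotometry, tested at 10 uM; a lower number here means less inhibition, a higher number more inhibition at the concentration tested (going by the name of the read-out). Compound 1 `O=C(C1CC1)N1CCN(Cc2nc3ccccc3n2Cc2ccccc2C(F)(F)F)CC1` gives 56.3%, compound 2 `Cc1cccc(Cn2c(OC3CCN(C(=O)C4CC4)CC3)nc3ccccc32)c1` gives 80.6%, and compound 3 `Cc1cccc(Cn2c(CN3CCN(C(=O)c4ccc(C#N)cc4)CC3)nc3ccccc32)c1` gives 20.8%, the lowest of the three, with compound 1 nearest and compound 2 furthest, both gaps beyond the scatter. Compound 4 `CCCC(=O)N1CCN(Cc2nc3ccccc3n2Cc2cccc(C)c2)CC1` has not yet been measured. The change from compound 3 to compound 4 is propyl in place of 4-cyanophenyl on a carbonyl carbon. Within the data shown here, no measured pair isolates this change, so the step in this assay can only be expected, not derived. The expectation is an upward step from compound 3 to compound 4 of a number 34.2 percentage points higher from compound 3 to compound 4 (beyond the scatter), because compound 1, carrying a cyclopropyl on the same carbonyl carbon, gives 56.3%. Compound 4 is therefore estimated at 55%, with a range from 30% to 80%.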

Compound 4, a percentage reported as inhibition, at one concentration (the size of the read-out at that concentration, not a potency): 79.1%
Estimate against measurement, compound 4: 24.1 percentage points below; low and high end bracket the measured number.
By their numbers in this assay, from the lowest: compound 3; then compound 1; then compounds 4 and 2 (each within the scatter of the next).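

In this assay the swap on the carbonyl carbon gives a number 58.3 percentage points higher from compound 3 to compound 4 (beyond the scatter), so the group held at this position can strongly change inhibition at the concentration tested. Among these compounds, this is the first pair of compounds that differ only here, and it sets an aromatic ring bearing a nitrile against an open chain. Nothing measured explains the size of this step. Going by these compounds, whether the ring or its nitrile goes with the lower number remains open. An unsubstituted phenyl or a longer chain such as pentyl at this position could begin to separate these possibilities.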